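A few compounds are considered here, and "the series" means these few. Any claim that something is new, unique, unknown or untested is made for them only; others in the source may bear on it.

Within the data shown here, in a functional assay on SMMC-7721 cells (Homo sapiens) for inhibition, read by MTT assay (a lower number here means a stronger inhibitor, a higher number a weaker inhibitor), two compounds built on a shared core have numbers so far. Compound 1 `N#CCC(=O)Nc1sc(C(=O)Nc2ccc(Cl)cc2)c(-c2ccccc2)c1C#N` gives 390 nM and compound 2 `CCOC(=O)c1c(NC(=O)CC#N)sc(C(=O)Nc2ccccc2)c1-c1ccccc1` gives 530 nM. These two values lie within the usual scatter of each other, so compound 2 stands level with compound 1 on the numbers at hand.

Compound 3 `N#CCC(=O)Nc1sc(C(=O)Nc2ccccc2)c(-c2ccccc2)c1C#N` has not yet been measured. It departs from compound 2 in one place: cyano in place of ethoxycarbonyl on an aromatic carbon. In short, compound 3 carries cyano where compound 2 carries ethoxycarbonyl.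

Among the measured compounds shown here, no measured pair shows this exchange alone, so the data give no direct size for it. For the measured compounds named here, the only guide is that compound 1 also carries the cyano group and gives 390 nM, a value within the scatter of the one for compound 2. In this assay, no step beyond the scatter is therefore expected, in either direction. The estimated change is a 1.2-fold lower number from compound 2 to compound 3 (0.06 log units; within the scatter). For compound 3 the expected value is 460 nM, with an estimated range from 210 nM to 1000 nM.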

Compound 3, half-maximal inhibitory concentration: 7930 nM
The estimate for compound 3 lay 17-fold (1.24 log units) below the measured number; measured number above the stated range.
By their numbers in this assay, from the lowest: compounds 1 and 2 (each within the scatter of the next); then compound 3.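

In this assay, the exchange of ethoxycarbonyl for cyano on this aromatic carbon, which bears on its two sides the ((cyanomethyl)carbonyl)amino and phenyl groups, is far from neutral: it brings a 15-fold higher number from compound 2 to compound 3 (1.17 log units; beyond the scatter). The chloro group counts just as heavily in the cyano series, since hydrogen in its place on an aromatic carbon brings a 20-fold higher number from compound 1 to compound 3 (1.31 log units; beyond the scatter). The level standing of compound 1 and compound 2 therefore did not mean that cyano and ethoxycarbonyl can stand in for each other: among these three, the number is low with either chloro or ethoxycarbonyl present and high only in compound 3, which carries neither.

The data offer no explanation for either large step. Still open, on these data alone, are whether the two steps would add up in a compound carrying both ethoxycarbonyl and chloro, and whether a carboxylic acid or a primary amide on the same aromatic carbon, or fluoro or methyl in place of chloro, would keep the number low.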